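Anilinopyrimidine series: amide variation at the aniline

A few compounds are considered here, and "the series" means these few. Any claim that something is new, unique, unknown or untested is made for them only; others in the source may bear on it.

Measured so far, as growth inhibition of KBVIN cells:
compound 1 `COc1ccc(N2CCN(C)CC2)cc1Nc1ncc(F)c(Nc2ccc(F)cc2)n1` — 910 nM
compound 2 `O=C(Nc1cccc(Nc2ncc(F)c(Nc3ccc(F)cc3)n2)c1)c1ccccc1` — > 10000 nM

Two compounds share the fluoropyrimidine core of compound 1 and differ in the aryl group carried on the amine. In a functional assay on KBVIN cells (Homo sapiens) for antiproliferative activity, read by sulforhodamine B assay, with a stated time of 3 days (on this read-out higher numbers stand for weaker inhibition of growth and lower numbers for stronger inhibition of growth), compound 1 gives 910 nM. For compound 2 this assay reports only a limit, > 10000 nM, so no number is known for it; it stands at the limit of > 10000 nM in this assay, at which 1 of the 2 values shown sits, and nothing beyond that limit can be read from it.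

Compound 3 `COCC(=O)Nc1cccc(Nc2ncc(F)c(Nc3ccc(F)cc3)n2)c1` is not yet measured. It keeps the amide of compound 2 and changes the acyl part: methoxymethyl in place of phenyl on a carbonyl carbon. Among the compounds with values here, no measured step exists for this kind of change, so the expectation rests on compound 2 alone, which is itself only a limit.

Since compound 2 sits at the limit, compound 3 is expected to stay near it, with the step from compound 2 to compound 3 estimated as a step that the limit leaves unreadable from compound 2 to compound 3, that is none beyond the scatter in either direction with clear confidence. For compound 3 the estimate in this assay is 12000 nM, with a range from 3000 nM to 40000 nM.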

Compound 3, concentration for 50% growth inhibition: 3940 nM
Beside the measured number, compound 3's estimate is 3.0-fold (0.48 log units) above it; low and high end bracket the measured number.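

In this assay, methoxymethyl in place of phenyl on a carbonyl carbon gives an at least 2.5-fold lower number from compound 2 to compound 3 (0.40 log units; beyond the scatter), so this acyl position of the amide tolerates a change that yields a readable growth-inhibition value. Compound 3 gives 3940 nM, which shows that, within this pair, a six-membered aromatic ring on the carbonyl carbon is not needed for a measurable effect on growth. The true size of the step stays unknown because the value for compound 2 is only a limit: the limit of > 10000 nM in this assay, at which 1 of the 3 values shown sits.

The pair changes ring loss, chain size and the ether oxygen together, so it leaves open which of these accounts for the step; a plain ethyl group or a methoxyethyl chain on the same carbonyl carbon would begin to separate them. Also open, as far as these compounds go, is how a dimethylaminomethyl group or a carboxylic acid at this place would read in this assay, and whether any acyl group here can take the series much further than compound 3.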